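Replacing the nitro group on the pendant aryl ring

A few compounds are considered here, and "the series" means these few. Any claim that something is new, unique, unknown or untested is made for them only; others in the source may bear on it.

The shared core carries a phenyl and a second aryl ring on adjacent saturated carbons. Compound 1 `COc1ccc2c(c1)OC(c1ccc(Cl)cc1)C(c1ccccc1)C2=O` gives 2410000 nM in a functional assay on HL-60 cells (Homo sapiens) for cytotoxicity, read by MTT assay, with a stated time of 5 days; a lower number here means that less compound is tolerated, a higher number that more compound is tolerated. Compound 2 `CCOc1ccc2c(c1)OC(c1cccc([N+](=O)[O-])c1)C(c1ccccc1)C2=O` reaches only a limit in this assay, > 2500000 nM (the limit of > 2500000 nM in this assay, at which 1 of the 3 values shown sits). Compound 3 `CCOc1ccc2c(c1)OC(c1ccc([N+](=O)[O-])cc1)C(c1ccccc1)C2=O`, in this assay, gives 203000 nM, the lowest of the two numbers shown; its nearest neighbour is compound 1, whose number is the higher of the two, a gap that lies beyond the usual scatter. Among the compounds with values here, the one measured step, an at least 12-fold lower number from compound 2 to compound 3 (1.09 log units; beyond the scatter), shows that moving the nitro group changes the number strongly.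

Compound 4 `CCOc1ccc2c(c1)OC(c1ccc(Cl)cc1)C(c1ccccc1)C2=O` differs from compound 3 by chloro in place of nitro on an aromatic carbon. Within the data shown here, no measured step covers this exchange directly, but compound 1 carries the same 4-chlorophenyl and gives 2410000 nM, while compound 3 with 4-nitrophenyl gives 203000 nM; compound 1 and compound 4 differ only in methoxy against ethoxy. Compound 4 is therefore expected to land near compound 1, a step of a 9.9-fold higher number from compound 3 to compound 4 (0.99 log units; beyond the scatter), an estimated 2000000 nM with a range from 600000 nM to 3000000 nM.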

Compound 4, half-maximal cytotoxic concentration: 514000 nM
The estimate for compound 4 lay 3.9-fold (0.59 log units) above the measured number; measured number below the stated range.
By their numbers in this assay, from the lowest: compound 3; then compound 4; then compound 1. At a limit, above all of these: compound 2.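

In this assay, the chloro-for-nitro exchange now has a direct measure with the ethoxy group held constant: a 2.5-fold higher number from compound 3 to compound 4 (0.40 log units; beyond the scatter) is a modest step beyond the scatter, and the 4-nitrophenyl compound keeps the lower number. Within the data shown here, the alkoxy group also counts, which the earlier compounds could not show, since a 4.7-fold lower number from compound 1 to compound 4 (0.67 log units; beyond the scatter) separates ethoxy from methoxy with the 4-chlorophenyl group kept. Compound 2 remains a limit, so an at least 4.8-fold lower number from compound 2 to compound 4 (0.68 log units; beyond the scatter) gives only a bound on the change from its 3-nitrophenyl group: the limit of > 2500000 nM in this assay, at which 1 of the 4 values shown sits.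

The compounds shown leave open how an amine or a carboxylic acid on that aromatic carbon would read. They also leave open whether a longer chain in place of ethoxy would lower the number further.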